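A Shorter Hydroxycarbamoyl Chain at the Assay Limit

This account rests on a few compounds, and the source may have more. Where it says the series, first, only, none or still open, it means among the compounds named here.

Measured in a functional assay on A549 cells (Homo sapiens) for inhibition, read by MTT assay, with a stated time of 72 h; on this read-out lower numbers stand for stronger inhibition and higher numbers for weaker inhibition:
- compound 1 `Nc1ncnc2c1c(-c1cnc3[nH]ccc3c1)nn2CCCCC(=O)NO`: > 150000 nM
- compound 2 `Nc1ncnc2c1c(-c1cnc3[nH]ccc3c1)nn2CCCCCC(=O)NO`: > 150000 nM
- compound 3 `Nc1nc2cc(-c3nn(CCCCC(=O)NO)c4ncnc(N)c34)ccc2o1`: > 100000 nM

None of these three entries is a number. All are limits, and the values shown sit at two of them: the limit of > 150000 nM in this assay, at which 2 of the 3 values shown sit, and (the limit of > 100000 nM in this assay, at which 1 of the 3 values shown sits).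

In this assay compound 2 gives > 150000 nM, which is a limit. Its position can therefore be told only as a bound, and it cannot be ranked against compound 1 or compound 3.

Compound 4 `Nc1ncnc2c1c(-c1cnc3[nH]ccc3c1)nn2CCCC(=O)NO` is the next compound to be read, and it differs from compound 2 in the chain: hydroxycarbamoyl in place of 2-(hydroxycarbamoyl)ethyl on a saturated chain carbon, three bonds along the chain from an aromatic nitrogen. Hydroxycarbamoyl enters in place of 2-(hydroxycarbamoyl)ethyl, on a saturated chain carbon, three bonds along the chain from an aromatic nitrogen. Cut one bond further out, this reads 5-(hydroxycarbamoyl)pentyl to 3-(hydroxycarbamoyl)propyl.

The closest measured change of chain length is a step that the two limits leave unreadable from compound 1 to compound 2. It offers no size and no direction to carry over. An estimated step of a number no higher from compound 2 to compound 4 (the limit leaves the size open) is therefore expected, with no real change foreseen in either direction. For compound 4 the expected value is 150000 nM, with an estimated range of 50000 nM to 300000 nM, and a further limit is the likeliest report.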

Compound 4, half-maximal inhibitory concentration: > 150000 nM
Compound 4: only a limit was reported; the forecaster's own chance of this, stated with the estimate: 80%; the middle value lies on the limit itself.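

In this assay compound 4 gives > 150000 nM, which is a limit and not a number. Among these compounds, its steps from compound 1 and from compound 2 cannot be read, and this result yields no new step. The compounds shown leave open how the length of the hydroxycarbamoyl chain bears on inhibition in this assay.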